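The source may report more compounds than this note shows. Statements on the series, on what has been measured and on what is new or still open speak of the compounds shown alone.

Working notes on the series. In a functional assay on A549 cells (Homo sapiens) for antiproliferative activity, read by MTT assay, with a stated time of 48 h (on this read-out higher numbers stand for weaker inhibition and lower numbers for stronger inhibition), compound 1 (`O=C(/C=C/c1ccc(/C=C/C(=O)c2cccc(Cl)c2)o1)NO`) gives 18900 nM and compound 2 (`CC(C)c1ccc(C(=O)/C=C/c2ccc(/C=C/C(=O)NO)o2)cc1`) gives 56700 nM. Compound 2 therefore holds the higher of the two numbers, meaning the weaker inhibition, and its gap to compound 1 lies beyond the scatter. Going by the values given here, no single-place step links these two compounds, so neither value isolates the effect of one change. The next compound is compound 3 (`Cc1ccc(C(=O)/C=C/c2ccc(/C=C/C(=O)NO)o2)cc1`), with methyl in place of isopropyl on an aromatic carbon. Among the compounds with values here, with only two readings available, the expectation is loose. In this assay, a modest move towards a lower number is expected, of a size near the scatter, with compound 1 at 18900 nM as the only nearby reference. The expected change is a 1.8-fold lower number from compound 2 to compound 3 (0.25 log units; within the scatter). For compound 3 the estimate is 32000 nM, with an expected range from 14000 nM to 70000 nM.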

Compound 3, half-maximal inhibitory concentration: 48600 nM
Compound 3: the middle estimate sits 1.5-fold (0.18 log units) below what was measured; the range from low to high includes it.
By their numbers in this assay, from the lowest: compound 1; then compounds 3 and 2 (each within the scatter of the next).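

In this assay, methyl in place of isopropyl on an aromatic carbon, para to a large group, gives a 1.2-fold lower number from compound 2 to compound 3 (0.07 log units; within the scatter), so these two alkyl groups are not told apart at this position. By contrast, 4-methylphenyl in place of 3-chlorophenyl on a carbonyl carbon gives a 2.6-fold higher number from compound 1 to compound 3 (0.41 log units; beyond the scatter), so of the two steps only the exchange of the whole substituted phenyl group moves the read-out beyond the scatter. No measurement at hand bears on why either step has the size it has.

Open, going by these compounds, is how an amine, a carboxylic acid or a methoxy group would read at the position that holds methyl and isopropyl. Also open, on these data alone, is whether a chlorine at that same position would carry the number of compound 3 towards that of compound 1.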